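The source may report more compounds than this note shows. Statements on the series, on what has been measured and on what is new or still open speak of the compounds shown alone.

Measured compounds in a functional assay on cells (Melanoma cell, Homo sapiens) for cytotoxicity, read by sulforhodamine B assay, with a stated time of 48 h; on this read-out higher numbers stand for weaker inhibition of growth and lower numbers for stronger inhibition of growth:
- compound 1 `COc1ccc(C2CC(c3ccccc3)=NN2C2=NC(=O)/C(=C3\C(=O)Nc4ccc(Br)cc43)S2)cc1`: 550 nM
- compound 2 `COc1ccc(C2=NN(C3=NC(=O)/C(=C4\C(=O)Nc5ccc(Br)cc54)S3)C(c3ccc(OC)cc3)C2)cc1`: 410 nM
- compound 3 `O=C1N=C(N2N=C(c3ccccc3)CC2c2ccc(Cl)cc2)S/C1=C1/C(=O)Nc2ccccc21`: 540 nM

Compound 1 and compound 2 differ in one place, (methoxy in place of hydrogen on an aromatic carbon). The step this change made in this assay is a 1.3-fold lower number from compound 1 to compound 2 (0.13 log units; within the scatter), so the two compounds cannot be separated on this read-out.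

Compound 3 carries a different core from compound 1; the difference between the two cores is not broken down here. Its value in this assay sits alongside those of compound 1 and compound 2, and none of the three is set apart.

Compound 4 `COc1ccc(C2=NN(C3=NC(=O)/C(=C4\C(=O)Nc5ccccc54)S3)C(c3ccc(Cl)cc3)C2)cc1` is not yet measured. It differs from compound 3 in one place, (methoxy in place of hydrogen on an aromatic carbon). This is the same change as that from compound 1 to compound 2, at a place described in the same terms. Among the measured compounds shown here, the expectation for the step from compound 3 to compound 4 is a 1.3-fold lower number from compound 3 to compound 4 (0.10 log units; within the scatter), resting on a 1.3-fold lower number from compound 1 to compound 2 (0.13 log units; within the scatter) as the one earlier instance of this change. Compound 4 is accordingly estimated at 430 nM in this assay, with the estimate expected to lie between 200 nM and 950 nM.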

Compound 4, concentration for total growth inhibition: 100000 nM
Compound 4: the middle estimate sits 230-fold (2.37 log units) below what was measured; measured number outside the range, above it.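

In this assay, methoxy in place of hydrogen on an aromatic carbon of the core of compound 3 gives a 190-fold higher number from compound 3 to compound 4 (2.27 log units; beyond the scatter), a large step in the direction of weaker inhibition of growth. This change cannot be carried from one core to the other in this series, as the two instances do not agree: the same change on two cores in this assay, a 1.3-fold lower number (0.13 log units; within the scatter) from compound 1 to compound 2 and a 190-fold higher number (2.27 log units; beyond the scatter) from compound 3 to compound 4, 250-fold (2.40 log units) apart, beyond the scatter of two such steps

With one instance on each core, the pair shows that the outcome of the change depends on the core it is made on, but it does not show which part of the difference between the cores is responsible, or how the change would behave on any further core.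

The compounds shown leave open whether the large step is specific to methoxy or would also appear with another group on the same aromatic carbon of the core of compound 3, such as a hydroxyl, an amine or a carboxylic acid. They also leave open whether a longer chain in place of methoxy would follow compound 4 or compound 3.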